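Bromo to nitro on the pendant phenyl ring

A few compounds are considered here, and "the series" means these few. Any claim that something is new, unique, unknown or untested is made for them only; others in the source may bear on it.

Measured so far:
compound 1 `Clc1ccc(Cc2nn3c(Br)c(-c4ccc(Br)cc4)nc3s2)cc1`: > 250000 nM
compound 2 `O=Cc1c(-c2ccc(Br)cc2)nc2sc(Cc3ccc(Cl)cc3)nn12`: 4600 nM

Among the compounds with values here, compound 2 `O=Cc1c(-c2ccc(Br)cc2)nc2sc(Cc3ccc(Cl)cc3)nn12` is the only member of the series with a number in a functional assay on L1210 cells (Mus musculus) for cytotoxicity, with a stated time of 48 h (a lower number here means a stronger inhibitor, a higher number a weaker inhibitor), where compound 2 gives 4600 nM. Compound 1 `Clc1ccc(Cc2nn3c(Br)c(-c4ccc(Br)cc4)nc3s2)cc1` gives only a limit in this assay, > 250000 nM, so its true value is not known. Within the data shown here, the one measured step, an at least 54-fold lower number from compound 1 to compound 2 (1.73 log units; beyond the scatter), therefore rests on a limit on one side the limit of > 250000 nM in this assay, at which 1 of the 2 values shown sits, and fixes only a minimum size.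

Compound 3 `O=Cc1c(-c2ccc([N+](=O)[O-])cc2)nc2sc(Cc3ccc(Cl)cc3)nn12` is not yet measured. It differs from compound 2 in one place: nitro in place of bromo on an aromatic carbon. Among the measured compounds shown here, this change sits on the pendant six-membered carbon ring, while the measured step concerned the other ring of the shared core, so no step on this kind of exchange exists, and the measured step gives no direct guide to it.

Without a comparable step, the expectation for compound 3 is a number near that of compound 2, with a change of no more than the usual scatter in this assay, in either direction; the estimated step is a 1.1-fold higher number from compound 2 to compound 3 (0.04 log units; within the scatter). Compound 3 is thus estimated at 5000 nM, within 1500 nM to 16000 nM.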

Compound 3, half-maximal inhibitory concentration: 15000 nM
Compound 3: middle estimate off by 3.0-fold (0.48 log units), on the low side; the range from low to high includes it.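

Exchanging 4-bromophenyl for 4-nitrophenyl gives a 3.3-fold higher number from compound 2 to compound 3 (0.51 log units; beyond the scatter) in this assay, so this position on the pendant ring responds to substitution, which compound 1 and compound 2, both carrying 4-bromophenyl, could not show. Of the two groups compared here, bromo goes with the lower number, while nitro, with its 2 hydrogen-bond acceptors against none for bromo, still leaves a measured number rather than a limit. Nothing measured on these compounds accounts for this step.

On these data alone, with only bromo and nitro compared at this position, it remains open how an amine, a methoxy group or a carboxylic acid there would read, and whether the same exchange would give a step of similar size with a group other than formyl on the shared core. As far as these compounds go, the size of the earlier step, an at least 54-fold lower number from compound 1 to compound 2 (1.73 log units; beyond the scatter), also remains open, as compound 1 gives only a limit: the limit of > 250000 nM in this assay, at which 1 of the 3 values shown sits.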